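A few compounds are considered here, and "the series" means these few. Any claim that something is new, unique, unknown or untested is made for them only; others in the source may bear on it.

Working notes on the series.

Three compounds have numbers in an assay on isolated protein for inhibition of Amine oxidase [flavin-containing] A (Homo sapiens); a lower number here means a stronger inhibitor, a higher number a weaker inhibitor. Compound 1 `CCN(CCCCCCOc1ccc(C(=O)/C=C/c2ccc(N(C)C)cc2)c(O)c1)Cc1ccccc1` gives 31600 nM. Compound 2 `CCN(CCCCOc1ccc(/C=C/C(=O)c2ccc(N(C)C)cc2O)cc1)Cc1ccccc1OC` gives 9200 nM, and compound 3 `COc1ccc(C(=O)/C=C/c2ccc(N(C)C)cc2)c(O)c1` gives 7620 nM. Compound 1 therefore stands at the highest number of the three: compound 2 is the nearest to it and compound 3 the furthest, and both lie beyond the scatter of repeated measurement, so compound 1 is the weakest inhibitor among the three measured.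

Compound 4 `CCN(CCCCCCOc1ccc(C(=O)/C=C/c2ccc(N(C)C)cc2)c(O)c1)Cc1ccccc1N(C)C` is not yet measured. It differs from compound 1 in one place: dimethylamino in place of hydrogen on an aromatic carbon, a dimethylamino in place of hydrogen on an aromatic carbon, placed ortho to a large group on the benzyl. Among the compounds with values here, no pair of measured compounds isolates this change, so its size in this assay is not known from the data. Compound 2 carries a methoxy on its benzyl, but it differs from compound 1 in more than one place, so its number says nothing on its own about a single substituent on the benzyl.

The expectation for compound 4 is a step from compound 1 of a 1.6-fold lower number from compound 1 to compound 4 (0.20 log units; within the scatter), a small move toward a lower number that may well fall within the scatter. Compound 4 is thus estimated at 20000 nM, with a range from 6000 nM to 60000 nM.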

Compound 4, half-maximal inhibitory concentration: 37800 nM
Estimate against measurement, compound 4: 1.9-fold (0.28 log units) below; the range from low to high includes it.
By their numbers in this assay, from the lowest: compounds 3 and 2 (each within the scatter of the next); then compounds 1 and 4 (each within the scatter of the next).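

Within the data shown here, the pair gives the first isolated reading of a substituent on the benzyl: in this assay, dimethylamino in place of hydrogen on an aromatic carbon, ortho to a large group, gives a 1.2-fold higher number from compound 1 to compound 4 (0.08 log units; within the scatter). This single change therefore leaves the number indistinguishable from that of the unsubstituted benzyl, so this dimethylamino group on the core of compound 1 gives no measurable gain or loss in this assay. No measured property of either compound bears on this result, so the data offer no account of it.

From the compounds shown here alone, only one substituent at this place has been compared directly with hydrogen, so it remains open whether a carboxylic acid, a fluorine or a primary amine at the same place would also leave the number within the scatter. Also open, going by these compounds, are whether dimethylamino elsewhere on the benzyl would behave in the same way, and whether the same change would read alike on a compound with a longer chain.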